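The source may hold more compounds than are shown below. What is called first, only, known or untested is meant among the compounds shown, and "the series" means these compounds.

Measured so far, in a functional assay on the whole organism (strain albino) for inhibition, with Rattus norvegicus as the target, read by paw edema, with stated times of 1 h and 3 h, at a dose of 25 mg/kg by the oral route; on this read-out lower numbers stand for less inhibition and higher numbers for more inhibition at the one dose given (going by the name of the read-out):
compound 1, `COc1ccc(/C=c2/sc3n(c2=O)C(c2ccc([N+](=O)[O-])cc2)C(C(=O)Nc2ccc(F)cc2)=C(C)N=3)cc1`, gives 12%
compound 2, `CC1=C(C(=O)Nc2ccc(F)cc2)C(c2ccc([N+](=O)[O-])cc2)n2c(s/c(=C/c3ccccc3)c2=O)=N1`, gives 7%
compound 3, `CC1=C(C(=O)Nc2ccc(F)cc2)C(c2ccc(Cl)cc2)n2c(s/c(=C/c3ccc(F)cc3)c2=O)=N1`, gives 44%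

Compound 3 stands highest of the three, with compound 1 nearest and compound 2 furthest, both gaps beyond the scatter. Compound 4, `CC1=C(C(=O)Nc2ccc(F)cc2)C(c2ccc(Cl)cc2)n2c(s/c(=C/c3ccccc3[N+](=O)[O-])c2=O)=N1`, has not yet been measured. It differs from compound 3 by 2-nitrophenyl in place of 4-fluorophenyl on a double-bonded chain carbon bound to an aromatic carbon. For the measured compounds named here, the one step measured so far, a number 5 percentage points lower from compound 1 to compound 2 (within the scatter), also sits on this same aryl group, but it swaps methoxy for hydrogen rather than fluorine for nitro, so it bears on the new step only loosely and shows no clear direction. The expected step in this assay is therefore a number 12 percentage points lower from compound 3 to compound 4 (beyond the scatter), a small fall that may well stay within the scatter. Compound 4 is estimated to give 32%, with a range from 12% to 50%.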

Compound 4, a percentage reported as inhibition, in the whole organism at one dose (the size of the read-out at that dose, not a potency): 16%
The estimate for compound 4 lay 16 percentage points above the measured number, within the range that was stated.
By their numbers in this assay, from the lowest: compounds 2, 1 and 4 (each within the scatter of the next); then compound 3.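

In this assay, 2-nitrophenyl in place of 4-fluorophenyl on this double-bonded chain carbon gives a number 28 percentage points lower from compound 3 to compound 4 (beyond the scatter). For the compounds shown here, the earlier step on this aryl group stayed within the scatter, so this is the first change here that clearly moves the read-out, which shows that the group at this place can matter. Nothing measured here explains the fall. The swap alters both the group on the ring and where it sits, and the compounds shown do not separate the two. Going by these compounds, how a ring carrying an amine or a carboxylic acid would behave here also stays open.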